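This account rests on a few compounds, and the source may have more. Where it says the series, first, only, none or still open, it means among the compounds named here.

Of the compounds shown here, two have been measured in an assay on isolated protein for inhibition of steroid 5-alpha-reductase (Rattus norvegicus); a lower number here means a stronger inhibitor, a higher number a weaker inhibitor. Compound 1 `COc1ccccc1N1CCN(CCC(Oc2ccc(NC(=O)c3ccccc3OCCCC(=O)O)cc2)c2ccc(C)cc2)CC1` gives 440 nM in this assay. Compound 2 `CCc1ccc(C(CCN2CCN(c3ccccc3OC)CC2)Oc2ccc(NC(=O)c3ccccc3OCCCC(=O)O)cc2)cc1` carries one more carbon on the chain attached to the ring at one end of the shared core, and in this assay compound 2 gives 130 nM. Going by the values given here, that single change is recorded as a 3.4-fold lower number from compound 1 to compound 2 (0.53 log units; beyond the scatter), so compound 2 stands as the lower of the two numbers known so far.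

Compound 3 `COc1ccccc1N1CCN(CCC(Oc2ccc(NC(=O)c3ccccc3OCCCC(=O)O)cc2)c2ccc(CC(C)C)cc2)CC1` has not yet been measured in this assay. It differs from compound 2 by isopropyl in place of methyl on a saturated chain carbon bound to an aromatic carbon. Among the compounds with values here, the only measured step that bears on this is the one from compound 1 to compound 2, where a small extension at the same place gave a modest lowering; here the extension is larger. On that basis a further modest lowering is expected, while a flattening or a reversal cannot be excluded from one step alone. The step from compound 2 to compound 3 is expected to be a 1.6-fold lower number from compound 2 to compound 3 (0.21 log units; within the scatter). Compound 3 is therefore estimated at 80 nM, within a range from 30 nM to 300 nM, in this assay.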

Compound 3, half-maximal inhibitory concentration: 96 nM
The estimate for compound 3 lay 1.2-fold (0.08 log units) below the measured number; low and high end bracket the measured number.
By their numbers in this assay, from the lowest: compounds 3 and 2 (each within the scatter of the next); then compound 1.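

Enlarging the group from 4-ethylphenyl to 4-isobutylphenyl gives no readable change in this assay (a 1.4-fold lower number from compound 2 to compound 3 (0.13 log units; within the scatter)), so compound 2 and compound 3 cannot be told apart, even though isopropyl brings in more carbon than methyl at this place. The gain over the smallest group in the series survives the larger group (a 4.6-fold lower number from compound 1 to compound 3 (0.66 log units; beyond the scatter)), which shows that this place on a saturated chain carbon bound to an aromatic carbon tolerates isopropyl as well as methyl, and that the difference from compound 1 is not lost with further branched bulk of carbon alone. Nothing available explains why these numbers fall as they do.

As far as these compounds go, with only three alkyl variants, all made of carbon and hydrogen, it stays open whether the trend flattens here or only appears to within the scatter, and a straight butyl chain or a cyclohexyl ring at this place could help to separate those readings. From the compounds shown here alone, it also stays open how this place responds to a group containing something other than carbon, such as a hydroxyl, an amine or a carboxylic acid.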